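Amide aryl variation on the shared core: compound 4

This account rests on a few compounds, and the source may have more. Where it says the series, first, only, none or still open, it means among the compounds named here.

Measured so far in a functional assay on HepG2 cells (Homo sapiens) for antiproliferative activity, read by CCK-8 assay, with a stated time of 72 h; a lower number here means a stronger inhibitor, a higher number a weaker inhibitor:
compound 1, `COc1cccc(C(=O)Nc2cccc(-c3oc4cc(-c5ccc(F)cc5)ccc4c(=O)c3O)c2)c1`: 9950 nM
compound 2, `CCc1ccc(C(=O)Nc2cccc(-c3oc4cc(-c5ccc(F)cc5)ccc4c(=O)c3O)c2)cc1`: 20600 nM
compound 3, `O=C(Nc1cccc(-c2oc3cc(-c4ccc(F)cc4)ccc3c(=O)c2O)c1)c1ccc(Br)cc1F`: > 100000 nM

For compound 3 this assay gives only a limit, (the limit of > 100000 nM in this assay, at which 1 of the 3 values shown sits), and no number. Compound 3 is thus the weakest of the three: an at least 10-fold higher number from compound 1 to compound 3 (1.00 log units; beyond the scatter) and an at least 4.8-fold higher number from compound 2 to compound 3 (0.68 log units; beyond the scatter), both beyond the scatter. Between the two compounds with a number, a 2.1-fold higher number from compound 1 to compound 2 (0.32 log units; beyond the scatter).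

Compound 4, `Cc1cc(C(=O)Nc2cccc(-c3oc4cc(-c5ccc(F)cc5)ccc4c(=O)c3O)c2)ccc1F`, is not yet measured. It differs from compound 3 in one place: 4-fluoro-3-methylphenyl in place of 4-bromo-2-fluorophenyl on a carbonyl carbon. The change returns the amide aryl group to a small, singly or doubly substituted phenyl of the kind carried by compound 1 and compound 2, both of which sit well inside the measurable range of this assay. The steps from compound 1 and compound 2 to compound 3 were each beyond the scatter, so undoing that kind of change is expected to bring compound 4 back toward their values rather than leave it at the limit.

Compound 4 is expected to give about 25000 nM in this assay, with a range from 8000 nM to 100000 nM; the step of an at least 4.0-fold lower number from compound 3 to compound 4 (0.60 log units; beyond the scatter) is estimated, though compound 3 itself is known only as a limit, so the true step may be larger.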

Compound 4, half-maximal inhibitory concentration: 9540 nM
Compound 4: the middle estimate sits 2.6-fold (0.42 log units) above what was measured; the measured number falls inside the stated range.
By their numbers in this assay, from the lowest: compounds 4 and 1 (each within the scatter of the next); then compound 2. At a limit, above all of these: compound 3.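

In this assay, 4-fluoro-3-methylphenyl in place of 4-bromo-2-fluorophenyl on a carbonyl carbon gives an at least 10-fold lower number from compound 3 to compound 4 (1.02 log units; beyond the scatter), so this position separates two aryl groups with the same heavy-atom count. Going by these compounds, the true size of that step stays open, as compound 3 is held only as a limit: the limit of > 100000 nM in this assay, at which 1 of the 4 values shown sits. The other two steps are a 1.0-fold lower number from compound 1 to compound 4 (0.02 log units; within the scatter) and a 2.2-fold lower number from compound 2 to compound 4 (0.33 log units; beyond the scatter), so 4-fluoro-3-methylphenyl and 3-methoxyphenyl cannot be told apart here, while 4-ethylphenyl stands apart from 4-fluoro-3-methylphenyl by a modest step.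

The shown compounds do not separate the contribution of the bromine from that of the fluorine in compound 3, as no compound carries either one alone on this phenyl. On these data alone, how an amine or a carboxylic acid on this phenyl would read also remains open.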